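From fluoro to 4-chlorophenoxy: a step still unmeasured

This account rests on a few compounds, and the source may have more. Where it says the series, first, only, none or still open, it means among the compounds named here.

Measured in an ADME assay on L6 cells (Rattus norvegicus) for cytotoxicity, read by resazurin assay; on this read-out lower numbers stand for stronger inhibition and higher numbers for weaker inhibition:
Compound 1 `N=C(N)c1ccc2[nH]c(-c3ccc4nc(-c5ccccc5F)[nH]c4c3)nc2c1` gives 26.8 ug/mL
Compound 2 `N=C(N)c1ccc2[nH]c(-c3ccc4nc(-c5ccc(F)cc5)[nH]c4c3)nc2c1` gives 2.48 ug/mL
Compound 3 `CC(C)(C)c1ccc(-c2nc3ccc(-c4nc5cc(C(=N)N)ccc5[nH]4)cc3[nH]2)cc1` gives 13 ug/mL

Compound 1 stands highest of these three, with compound 3 nearest to it and compound 2 furthest away. Compound 4 `N=C(N)c1ccc2[nH]c(-c3ccc4nc(-c5ccccc5Oc5ccc(Cl)cc5)[nH]c4c3)nc2c1` has not yet been measured. It differs from compound 1 by a single change (4-chlorophenoxy in place of fluoro on an aromatic carbon), namely 4-chlorophenoxy in place of fluoro on an aromatic carbon, ortho to a large group.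

Two measured steps replace the whole 2-fluorophenyl group of compound 1. The large step of an 11-fold lower number from compound 1 to compound 2 (1.03 log units; beyond the scatter) and the modest step of a 2.1-fold lower number from compound 1 to compound 3 (0.31 log units; beyond the scatter) both lead to lower numbers in this assay. The step of a 5.2-fold higher number from compound 2 to compound 3 (0.72 log units; beyond the scatter) shows that the size of the drop differs from one group to another. Among the compounds with values here, no measured compound carries anything but fluoro at the place that changes here, so this evidence is indirect. A lower number is still expected, with a drop closer to the modest step than to the large one. The expected step is a 3.8-fold lower number from compound 1 to compound 4 (0.58 log units; beyond the scatter) and it remains an estimate. For compound 4 the estimated value is 7 ug/mL, with an expected range from 2 ug/mL to 22 ug/mL.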

Compound 4, half-maximal inhibitory concentration: > 90 ug/mL
Compound 4 ended at the assay's limit; the forecaster's own chance of this, stated with the estimate: 5%; at least 12-fold (1.10 log units) between middle value and limit.
By their numbers in this assay, from the lowest: compound 2; then compound 3; then compound 1. At a limit, above all of these: compound 4.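

In this assay, compound 4 sits at the limit of the read-out, so its value is a limit and not a number: the limit of > 90 ug/mL in this assay, at which 1 of the 4 values shown sits. This is the only step shown that changes this aromatic carbon, ortho to a large group, and with an at least 3.3-fold higher number from compound 1 to compound 4 (0.52 log units; beyond the scatter) it runs in the opposite direction to the two steps that replace the whole 2-fluorophenyl group, an 11-fold lower number from compound 1 to compound 2 (1.03 log units; beyond the scatter) and a 2.1-fold lower number from compound 1 to compound 3 (0.31 log units; beyond the scatter). The lower numbers of those earlier steps therefore do not carry over to 4-chlorophenoxy in place of fluoro at this position, where the number in this assay rises instead, by an amount that the limit leaves unknown.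

Among the compounds shown, this place carries a group only in compound 1 and compound 4, so it remains open whether the rise belongs to 4-chlorophenoxy in particular or would come with other groups here. A plain phenoxy without the chlorine, a methoxy or an amine at this place would help to settle that, and the compounds shown do not say how any of them would read.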